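The source may report more compounds than this note shows. Statements on the series, on what has been measured and on what is new or still open speak of the compounds shown alone.

Compound 1 `Cc1ccccc1-n1nncc1CN1C(=O)C2(C(C#N)=C(N)Oc3c2c2nc4ccccc4nc2c2ccccc32)c2ccccc21`: > 50000 nM
Compound 2 `N#CC1=C(N)Oc2c(c3nc4ccccc4nc3c3ccccc23)C12C(=O)N(Cc1cnnn1-c1cccc(Br)c1)c1ccccc12`: > 50000 nM
Compound 3 `N#CC1=C(N)Oc2c(c3nc4ccccc4nc3c3ccccc23)C12C(=O)N(Cc1cnnn1-c1ccc(S(N)(=O)=O)cc1)c1ccccc12`: 31200 nM

All three were tested in a functional assay on HCT-116 cells (Homo sapiens) for antiproliferative activity, read by MTT assay, with a stated time of 48 h; a lower number here means a stronger inhibitor, a higher number a weaker inhibitor. Compound 1 gives only a limit there: > 50000 nM. Compound 2 likewise gives only a limit: > 50000 nM. Compound 3 gives a number, 31200 nM. The not yet measured compound 4 `Cc1ccc(-n2nncc2CN2C(=O)C3(C(C#N)=C(N)Oc4c3c3nc5ccccc5nc3c3ccccc43)c3ccccc32)cc1Cl` differs from compound 1 in one place: 3-chloro-4-methylphenyl in place of 2-methylphenyl on an aromatic nitrogen. Two measured steps start from compound 1. The step that the two limits leave unreadable from compound 1 to compound 2 cannot be sized, because both of its values sit at the limit of > 50000 nM in this assay, at which 2 of the 3 values shown sit. The step of an at least 1.6-fold lower number from compound 1 to compound 3 (0.20 log units; that floor lies within the scatter) is only a floor, and that floor lies within the scatter. The group entering in compound 4 carries a chlorine, much as the 3-bromophenyl of compound 2 carries a bromine, while the sulfamoyl group that set compound 3 apart is absent. For compound 4 the expectation is therefore no step beyond the scatter, a step that the limit leaves unreadable from compound 1 to compound 4. The estimate for compound 4 is 60000 nM, between 25000 nM and 150000 nM, most likely reported again only as a limit.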

Compound 4, half-maximal inhibitory concentration: > 50000 nM
Compound 4 ended at the assay's limit; the forecaster's own chance of this, stated with the estimate: 70%; the middle value does not contradict the limit.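

With 3-chloro-4-methylphenyl on the aromatic nitrogen of the five-membered ring, a third compound now stands at a limit in this assay, so compounds 1, 2 and 4 all behave alike there, and compound 3, with its 4-sulfamoylphenyl, is the one exception. The steps from compound 1 and from compound 2 to compound 4 cannot be read, since each joins two limits: the limit of > 50000 nM in this assay, at which 3 of the 4 values shown sit.

Among these compounds, the one readable comparison is an at least 1.6-fold higher number from compound 3 to compound 4 (0.20 log units; that floor lies within the scatter), which is only a floor and does not establish a real gap.

From the compounds shown here alone, how far compounds 1, 2 and 4 lie past the limit stays open. So does whether a phenyl ring carrying an amine or a carboxylic acid would give a measurable number, as the 4-sulfamoylphenyl of compound 3 does.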